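Chloro for Methoxy in a Series at the Assay Limit

This account rests on a few compounds, and the source may have more. Where it says the series, first, only, none or still open, it means among the compounds named here.

Compound 1 `C=C1C[C@]23C[C@@]1(O)CC[C@@H]2c1cccc(C)c1[C@@H]3Cn1cc(-c2ccc(OC)cc2)nn1` was examined in a functional assay on HL-60 cells (Homo sapiens) for cytotoxicity, read by MTT assay, with a stated time of 4 days; on this read-out higher numbers stand for weaker inhibition and lower numbers for stronger inhibition. In this assay compound 1 gives only a limit, > 20000 nM. Compound 2 `C=C1C[C@]23C[C@@]1(O)CC[C@H]2c1cc(Br)c(O)c(C)c1[C@@H]3Cn1cc(-c2ccc(OC)cc2)nn1` likewise reaches only a limit in this assay, > 20000 nM. Compound 3 `C=C1C[C@]23C[C@@]1(O)CC[C@H]2c1ccc(O)c(C)c1[C@@H]3Cn1cc(-c2ccc(Br)cc2)nn1` also gives nothing but a limit, > 20000 nM. Compound 1 therefore stands exactly where the other two stand, at the limit of the assay: the limit of > 20000 nM in this assay, at which 3 of the 3 values shown sit. Going by the values given here, no step between measured compounds can be drawn, since every value shown is a limit rather than a number.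

Compound 4 `C=C1C[C@]23C[C@@]1(O)CC[C@@H]2c1cccc(C)c1[C@@H]3Cn1cc(-c2ccc(Cl)cc2)nn1` differs from compound 1 by chloro in place of methoxy on an aromatic carbon. Among the compounds with values here, with no measured step to lean on, and with compound 1 sitting at the limit > 20000 nM, nothing points to a shift beyond the scatter in either direction. The expected step is accordingly a step that the limit leaves unreadable from compound 1 to compound 4, that is, none worth noting. Compound 4 is estimated at 25000 nM, with a range from 6000 nM to 100000 nM, and most likely again only a limit will be reported.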

Compound 4, half-maximal inhibitory concentration: > 20000 nM
Compound 4: a limit, no number; the forecaster's own chance of this, stated with the estimate: 80%; the middle value is on the limit's open side.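

In this assay compound 4 gives > 20000 nM as a limit and not a number. Going by these compounds alone, compound 1 also gives only a limit, so no step between compound 1 and compound 4 can be read: the limit of > 20000 nM in this assay, at which 4 of the 4 values shown sit. The compounds shown leave open whether chloro in place of methoxy changes the read-out at all, since none of them yields a number.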